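The compounds below may be only part of what the source reports. "The series", "measured", "known", "first", "only" and "open" are said of these compounds alone.

Compound 2 `OC[C@H]1O[C@@H](n2cnc3c(NCc4ccc(F)cc4Cl)ncnc32)[C@H](O)[C@@H]1O` gives 9000 nM in a functional assay on HL-60 cells (Homo sapiens) for antiproliferative activity, with a stated time of 72 h (a lower number here means a stronger inhibitor, a higher number a weaker inhibitor), the higher of the two numbers recorded so far; compound 1 `OC[C@H]1O[C@@H](n2cnc3c(NCc4ccc(Cl)cc4)ncnc32)[C@H](O)[C@@H]1O` gives 1700 nM. Going by the values given here, the only measured step, a 5.3-fold higher number from compound 1 to compound 2 (0.72 log units; beyond the scatter), is the sole guide. Compound 3 `COc1cccc(CNc2ncnc3c2ncn3[C@@H]2O[C@H](CO)[C@@H](O)[C@H]2O)c1O` differs from compound 2 by 2-hydroxy-3-methoxyphenyl in place of 2-chloro-4-fluorophenyl on a saturated chain carbon bound to a nitrogen on an aromatic ring. Among the compounds with values here, that earlier step changed the same place and moved the number modestly, so a shift of comparable size is plausible here, but no measured step involves a hydroxy or methoxy group, so the direction is uncertain. Compound 3 is expected to land near the measured pair, with a step of a 3.0-fold lower number from compound 2 to compound 3 (0.48 log units; beyond the scatter), estimated at 3000 nM within 800 nM to 12000 nM.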

Compound 3, half-maximal inhibitory concentration: 150 nM
Estimate against measurement, compound 3: 20-fold (1.30 log units) above; measured number outside the range, below it.
By their numbers in this assay, from the lowest: compound 3; then compound 1; then compound 2.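

In this assay the place on a saturated chain carbon bound to a nitrogen on an aromatic ring proves far more responsive than the halogen swap indicated: 2-hydroxy-3-methoxyphenyl in place of 2-chloro-4-fluorophenyl gives a 60-fold lower number from compound 2 to compound 3 (1.78 log units; beyond the scatter) and, in place of 4-chlorophenyl, gives an 11-fold lower number from compound 1 to compound 3 (1.05 log units; beyond the scatter) at the same place. Compound 3 therefore has the lowest number of the three, with both steps beyond the scatter. No available evidence bears on the reason for this gain.

From the compounds shown here alone, whether the hydroxy group, the methoxy group or only the two together carry the gain remains open. Also open, going by these compounds, is how an amine or a carboxylic acid on this ring, or a longer chain to it, would compare.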